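Swapping Ethyl for a Branched Ether Chain on Compound 3

The source may report more compounds than this note shows. Statements on the series, on what has been measured and on what is new or still open speak of the compounds shown alone.

Compound 1 `COC(=O)CCn1cc(C(=O)C(=O)Nc2ccc(OC)nc2)c2ccccc21`: 168 nM
Compound 2 `COc1ccc(NC(=O)C(=O)c2cn(CC3CCCO3)c3ccccc23)cn1`: 31 nM
Compound 3 `CCn1cc(C(=O)C(=O)Nc2ccc(OC)nc2)c2ccccc21`: 219 nM

In a functional assay on FaDu cells (Homo sapiens) for cytotoxicity, read by MTT assay, with a stated time of 72 h (a higher number here means that more compound is tolerated, a lower number that less compound is tolerated), compound 3 gives the highest of the three numbers. Compound 1 sits close to it, since a 1.3-fold higher number from compound 1 to compound 3 (0.12 log units; within the scatter) lies within the scatter, whereas compound 2 sits well below it, as a 7.1-fold higher number from compound 2 to compound 3 (0.85 log units; beyond the scatter) shows. Compound 4 `COCC(C)(C)n1cc(C(=O)C(=O)Nc2ccc(OC)nc2)c2ccccc21` differs from compound 3 by 1-(methoxymethyl)-1-methylethyl in place of ethyl on an aromatic nitrogen. For the measured compounds named here, the step that bears on this is the one from compound 2 to compound 3, where methyl in place of oxolan-2-yl on the chain at the aromatic nitrogen went with the higher number; the change from compound 1 to compound 3 on that chain stayed within the scatter. A modest downward step is therefore expected, a 2.4-fold lower number from compound 3 to compound 4 (0.39 log units; beyond the scatter). Compound 4 is estimated at 90 nM, between 35 nM and 230 nM.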

Compound 4, concentration lethal to 50% of the cells: 137 nM
Estimate against measurement, compound 4: 1.5-fold (0.18 log units) below; the measured number falls inside the stated range.
By their numbers in this assay, from the lowest: compound 2; then compounds 4, 1 and 3 (each within the scatter of the next).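

In this assay, 1-(methoxymethyl)-1-methylethyl on the aromatic nitrogen stays within the scatter of ethyl (a 1.6-fold lower number from compound 3 to compound 4 (0.20 log units; within the scatter)) and of 2-(methoxycarbonyl)ethyl (a 1.2-fold lower number from compound 1 to compound 4 (0.09 log units; within the scatter)). Only (oxolan-2-yl)methyl remains apart (a 4.4-fold higher number from compound 2 to compound 4 (0.65 log units; beyond the scatter)), so an ether oxygen in an open chain at this position does not by itself go with the low number of compound 2. The compounds shown leave open whether an amine, a carboxylic acid or a longer chain at this nitrogen would stay with compounds 1, 3 and 4 or move toward compound 2. No information on the cause of these steps is available.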